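Fluoro to chloro step carried onto a second core

A few compounds are considered here, and "the series" means these few. Any claim that something is new, unique, unknown or untested is made for them only; others in the source may bear on it.

Three compounds are measured in a functional assay on HL-60 cells (Homo sapiens) for cytotoxicity, read by MTT assay, with a stated time of 72 h; on this read-out higher numbers stand for weaker inhibition and lower numbers for stronger inhibition. Compound 1 `O=S(=O)(c1ccccc1)c1nc2ccccc2nc1Nc1ccc(F)cc1` gives 1010 nM. Compound 2 `O=S(=O)(c1ccccc1)c1nc2ccccc2nc1Nc1ccc(Cl)cc1` differs from compound 1 by chloro in place of fluoro on an aromatic carbon; in this assay compound 2 gives 1920 nM, and the change a 1.9-fold higher number from compound 1 to compound 2 (0.28 log units; within the scatter). Compound 3 `Cc1ccc(S(=O)(=O)c2nc3ccccc3nc2Nc2ccc(F)cc2)cc1` gives 5100 nM. The core of compound 3 differs from the core of compound 1 by methyl in place of hydrogen on an aromatic carbon, and this change a 5.0-fold higher number from compound 1 to compound 3 (0.70 log units; beyond the scatter). Compound 3 thus stands at the highest number of the three, beyond the scatter from both compound 1 and compound 2.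

Compound 4 `Cc1ccc(S(=O)(=O)c2nc3ccccc3nc2Nc2ccc(Cl)cc2)cc1` is not yet measured. It differs from compound 3 by chloro in place of fluoro on an aromatic carbon. This is the same change as that from compound 1 to compound 2, made at the same place on the same kind of ring, only on the core of compound 3 rather than the core of compound 1. Within the data shown here, because the single measured instance, a 1.9-fold higher number from compound 1 to compound 2 (0.28 log units; within the scatter), lies within the scatter, a similar small step is expected here: compound 4 is expected to show a 1.6-fold higher number from compound 3 to compound 4 (0.20 log units; within the scatter). Among the measured compounds shown here, with only one precedent for this change and none on the core of compound 3, the range is kept wide. Compound 4 is estimated at 8000 nM. The expected interval for compound 4 runs from 3500 nM to 18000 nM.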

Compound 4, half-maximal inhibitory concentration: 17500 nM
Beside the measured number, compound 4's estimate is 2.2-fold (0.34 log units) below it; measured number inside the range.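

In this assay, chloro in place of fluoro on the core of compound 3 gives a 3.4-fold higher number from compound 3 to compound 4 (0.54 log units; beyond the scatter), a step in the same direction as on the core of compound 1, and the two steps do not differ beyond the scatter: the same change on two cores in this assay, a 1.9-fold higher number (0.28 log units; within the scatter) from compound 1 to compound 2 and a 3.4-fold higher number (0.54 log units; beyond the scatter) from compound 3 to compound 4, 1.8-fold (0.26 log units) apart, within the scatter of two such steps. Methyl in place of hydrogen, read on the chloro pair, gives a 9.1-fold higher number from compound 2 to compound 4 (0.96 log units; beyond the scatter), again in the same direction as on the fluoro pair and again with no difference beyond the scatter: the same change on two cores in this assay, a 5.0-fold higher number (0.70 log units; beyond the scatter) from compound 1 to compound 3 and a 9.1-fold higher number (0.96 log units; beyond the scatter) from compound 2 to compound 4, 1.8-fold (0.26 log units) apart, within the scatter of two such steps. Within these four compounds, both changes carry from one core to the other in direction and, within the scatter, in size, but each rests on only two steps, the chloro step stands clear of the scatter on the core of compound 3 alone, and nothing here shows that the pattern extends past this set or explains why either change raises the number.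

On these data alone, whether a bromo, a methoxy or an amine in the place of fluoro and chloro would continue the same trend stays open, as does whether an ethyl or a longer chain in the place of methyl would add to the step. As far as these compounds go, whether either step holds in cells other than those of this assay is also open.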